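Thienyl exchange on two related cores

The source may report more compounds than this note shows. Statements on the series, on what has been measured and on what is new or still open speak of the compounds shown alone.

Measured in a functional assay on cells (Cancer cell lines, Homo sapiens) for inhibition; on this read-out higher numbers stand for weaker inhibition of growth and lower numbers for stronger inhibition of growth:
compound 1 `N=C(N)N/N=C/c1c(-c2cccs2)nc2sccn12` gives 25700 nM
compound 2 `Cc1cc(-c2nc3sccn3c2/C=N/NC(=N)N)c(C)s1` gives 30200 nM
compound 3 `Cc1cc(-c2nc3n(c2/C=N/NC(=N)N)CCS3)c(C)s1` gives 34700 nM

Compounds 1 and 2 share one core; compound 3 carries another, and the difference between the two cores is not broken down here. All three values lie within the scatter of one another. On the first core, the change thiophen-2-yl in place of 2,5-dimethylthiophen-3-yl on an aromatic carbon produced a 1.2-fold lower number from compound 2 to compound 1 (0.07 log units; within the scatter).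

Compound 4 `N=C(N)N/N=C/c1c(-c2cccs2)nc2n1CCS2` applies the same kind of change to the core of compound 3: thiophen-2-yl in place of 2,5-dimethylthiophen-3-yl on an aromatic carbon. Around the place, this second description adds that the carbon lies two ring bonds from two ring atoms that each bear a fused ring.

Because a 1.2-fold lower number from compound 2 to compound 1 (0.07 log units; within the scatter) stayed within the scatter, a similarly small step is expected for compound 4 in this assay. The expected step is a 1.2-fold lower number from compound 3 to compound 4 (0.08 log units; within the scatter). Compound 4 is estimated at 29000 nM, between 12000 nM and 70000 nM.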

Compound 4, concentration for total growth inhibition: 39800 nM
Estimate against measurement, compound 4: 1.4-fold (0.14 log units) below, within the range that was stated.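

In this assay, thiophen-2-yl in place of 2,5-dimethylthiophen-3-yl on the core of compound 3 gave a 1.1-fold higher number from compound 3 to compound 4 (0.06 log units; within the scatter). The same exchange on the two cores gave steps that cannot be told apart: the same change on two cores in this assay, a 1.2-fold lower number (0.07 log units; within the scatter) from compound 2 to compound 1 and a 1.1-fold higher number (0.06 log units; within the scatter) from compound 3 to compound 4, 1.3-fold (0.13 log units) apart, within the scatter of two such steps. The change therefore carries from one core to the other as a step within the scatter, but no direction can be read from either step, and two pairs do not show that it would stay this small on any further core.

The compounds shown hold only these two thienyl groups at this place. From the compounds shown here alone, whether a phenyl ring, an amine or a carboxylic acid there would move the number beyond the scatter remains open.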